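The source may hold more compounds than are shown below. What is called first, only, known or untested is meant among the compounds shown, and "the series" means these compounds.

The measured compounds: compound 1 `CN(C(=O)NC(=O)c1cccc(C(F)(F)F)c1)c1nc(C(F)(F)F)c(C(=O)N/N=C/c2cc(C(F)(F)F)cc(C(F)(F)F)c2)s1` with 6.08 ug/mL; compound 2 `CN(C(=O)NC(=O)c1ccc([N+](=O)[O-])cc1)c1nc(C(F)(F)F)c(C(=O)N/N=C/c2cccc(C(F)(F)F)c2)s1` with 4.39 ug/mL; compound 3 `CN(C(=O)NC(=O)c1ccccc1F)c1nc(C(F)(F)F)c(C(=O)N/N=C/c2cccc(C(F)(F)F)c2)s1` with 20.5 ug/mL.

In a functional assay on MCF7 cells (Homo sapiens) for inhibition, read by MTT assay, with a stated time of 72 h (a higher number here means a weaker inhibitor, a lower number a stronger inhibitor), compound 3 gives the highest of the three numbers, and both other compounds stand beyond the scatter from it. Going by the values given here, the step of a 4.7-fold higher number from compound 2 to compound 3 (0.67 log units; beyond the scatter) is the only measured change at the carbonyl carbon, and it shows that swapping the aryl group there moves the number by a modest amount.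

Compound 4 `CN(C(=O)NC(=O)c1cccc(C(F)(F)F)c1)c1nc(C(F)(F)F)c(C(=O)N/N=C/c2cccc(C(F)(F)F)c2)s1` differs from compound 3 by 3-(trifluoromethyl)phenyl in place of 2-fluorophenyl on a carbonyl carbon. Among the compounds with values here, no measured pair shows exactly this exchange. Compound 1 carries the same 3-(trifluoromethyl)phenyl group on its carbonyl carbon but a different hydrazone arene, so its value can only be noted alongside that of compound 3 rather than used as a step. Given that the one change at this position altered the number modestly, and that compound 3 holds the weakest value, compound 4 is expected to show a step of a 2.6-fold lower number from compound 3 to compound 4 (0.41 log units; beyond the scatter) towards a lower number. Compound 4 is therefore estimated at 8 ug/mL, within 3 ug/mL to 25 ug/mL.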

Compound 4, half-maximal inhibitory concentration: 3.7 ug/mL
For compound 4 the middle estimate is 2.2-fold (0.33 log units) above the measured one; measured number inside the range.
By their numbers in this assay, from the lowest: compounds 4, 2 and 1 (each within the scatter of the next); then compound 3.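

In this assay, the second measured change on the carbonyl carbon, a 5.5-fold lower number from compound 3 to compound 4 (0.74 log units; beyond the scatter), shows that this position can shift the number in the lower direction as well, and the step is of similar size to the earlier one. Two quite different aryl groups on this carbon, 4-nitrophenyl and 3-(trifluoromethyl)phenyl, give numbers that cannot be told apart, as a 1.2-fold lower number from compound 2 to compound 4 (0.07 log units; within the scatter) shows, so among the three groups shown only 2-fluorophenyl stands apart. The hydrazone arene gives its first single-place comparison, and a 1.6-fold lower number from compound 1 to compound 4 (0.22 log units; within the scatter) leaves a second trifluoromethyl group there without a readable effect; nothing measured here explains any of these steps.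

The compounds shown leave open where a plain phenyl ring or an aminophenyl group on the carbonyl carbon would fall. They also leave open whether a carboxylic acid on the hydrazone arene would stay within the scatter of compound 4.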